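The compounds below may be only part of what the source reports. "The series", "measured", "known", "first", "only" and "open" are said of these compounds alone.

Measured compounds:
- compound 1 `O=C(O)c1csc([C@H]2CC[C@@H]3[C@@H](COc4cccc(F)c4)[C@H](O)C[C@@H]3O2)n1`: 5.4 nM in a functional assay on CHO cells for agonist activity at prostaglandin E2 receptor EP2 subtype (Homo sapiens), read by HTRF and cAMP accumulation, with a stated time of 30 min; a lower number here means that less compound is needed, a higher number that more compound is needed for the effect
- compound 2 `O=C(O)c1csc([C@H]2CC[C@@H]3[C@@H](COc4cccc(Cl)c4)[C@H](O)C[C@@H]3O2)n1`: 6.5 nM
- compound 3 `O=C(O)c1csc([C@H]2CC[C@@H]3[C@@H](COc4ccc(F)cc4)[C@H](O)C[C@@H]3O2)n1`: 7 nM

Compound 3 carries the highest of the three numbers, but the step of a 1.3-fold higher number from compound 1 to compound 3 (0.11 log units; within the scatter) and the step of a 1.1-fold higher number from compound 2 to compound 3 (0.03 log units; within the scatter) are both within the scatter, so the three compounds are indistinguishable on the numbers shown. The step of a 1.2-fold higher number from compound 1 to compound 2 (0.08 log units; within the scatter) is likewise within the scatter.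

Compound 4 `O=C(O)c1csc([C@H]2CC[C@@H]3[C@@H](COc4ccccc4C(F)(F)F)[C@H](O)C[C@@H]3O2)n1` differs from compound 3 by 2-(trifluoromethyl)phenyl in place of 4-fluorophenyl on an oxygen on a saturated carbon. The measured steps bear on it only loosely: they show that moving a fluorine around the phenyl, or exchanging fluorine for chlorine, leaves the number where it was. None of them introduces a trifluoromethyl or a substituent in the place named in 2-(trifluoromethyl)phenyl, so the present change lies outside the sampled ground. The expectation for compound 4 is therefore a step of a 1.7-fold higher number from compound 3 to compound 4 (0.23 log units; within the scatter), that is a modestly higher number with wide uncertainty. Compound 4 is estimated at 12 nM, within 3 nM to 50 nM.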

Compound 4, half-maximal effective concentration: 0.5 nM
Beside the measured number, compound 4's estimate is 24-fold (1.38 log units) above it; the measured number lies below the stated range.
By their numbers in this assay, from the lowest: compound 4; then compounds 1, 2 and 3 (each within the scatter of the next).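

At this position, on an oxygen on a saturated carbon, the aryl group is less indifferent than compounds 1, 2 and 3 suggested: in this assay, 2-(trifluoromethyl)phenyl gives a 14-fold lower number from compound 3 to compound 4 (1.15 log units; beyond the scatter), with a 13-fold lower number from compound 2 to compound 4 (1.11 log units; beyond the scatter) and an 11-fold lower number from compound 1 to compound 4 (1.03 log units; beyond the scatter) alongside it, all beyond the scatter. For the compounds shown here, the single fluoro or chloro groups of the earlier compounds gave only steps within the scatter, so this is the first change on this aryl group that shifts the number by a large step. Nothing shown here accounts for the size of the step.

As far as these compounds go, whether the step belongs to the trifluoromethyl itself or to its place in 2-(trifluoromethyl)phenyl stays open: compound 4 alone carries a trifluoromethyl, and it alone has a substituent in that place. From the compounds shown here alone, how a methyl, a methoxy or a nitrile in that same place would compare also remains unknown.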